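Swapping the sulfur-bound ethyl for a cyclopropylmethyl

The source may report more compounds than this note shows. Statements on the series, on what has been measured and on what is new or still open speak of the compounds shown alone.

Compound 3 `CCSc1nc(Nc2cccc(OC)c2)c2ccncc2n1` gives 590 nM in a functional assay on MGC-803 cells (Homo sapiens) for inhibition, read by MTT assay, with a stated time of 72 h (on this read-out higher numbers stand for weaker inhibition and lower numbers for stronger inhibition), the lowest number among the two measured values; compound 2 `C#CCSc1nc(Nc2cccc(Cl)c2)c2ccncc2n1` sits higher at 2190 nM. Compound 1 `C#CCSc1nc(NCCC(C)C)c2ccncc2n1` reaches only the assay limit, > 80000 nM. Compound 4 `COc1cccc(Nc2nc(SCC3CC3)nc3cnccc23)c1` differs from compound 3 by one change: cyclopropyl in place of methyl on a saturated chain carbon bound to a sulfur. Within the data shown here, the single measured step, an at least 36-fold lower number from compound 1 to compound 2 (1.56 log units; beyond the scatter), changes the group on the ring nitrogen, not the sulfur chain, so no measured step speaks to this change. Compound 4 is therefore expected to stay close to compound 3, with a step of a 1.3-fold lower number from compound 3 to compound 4 (0.12 log units; within the scatter) that lies within the scatter. The estimate for compound 4 is 450 nM, within a range from 150 nM to 1500 nM.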

Compound 4, half-maximal inhibitory concentration: 1340 nM
For compound 4 the middle estimate is 3.0-fold (0.47 log units) below the measured one; the measured number falls inside the stated range.
By their numbers in this assay, from the lowest: compound 3; then compounds 4 and 2 (each within the scatter of the next). At a limit, above all of these: compound 1.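

Cyclopropyl in place of methyl on a saturated chain carbon bound to a sulfur gives a 2.3-fold higher number from compound 3 to compound 4 (0.36 log units; beyond the scatter). Among these compounds, this is the first measured sign that the sulfur chain, and not only the group on the nitrogen, can shift the number, and here the shift is towards weaker inhibition. No measured property among the data shown accounts for this step.

As far as these compounds go, whether a plain longer chain such as butyl, or a chain ending in an amine, would weaken inhibition further or restore it remains open. So does whether the same swap behaves alike with 3-chlorophenyl on the nitrogen.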